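The compounds below may be only part of what the source reports. "The series", "measured", "known", "first", "only" and "open" are said of these compounds alone.

Measured so far in a functional assay on HCT-116 cells (Homo sapiens) for cytotoxicity, read by MTT assay, with a stated time of 72 h; a higher number here means a weaker inhibitor, a lower number a stronger inhibitor:
- compound 1 `NCc1nnc(-c2cc(S(N)(=O)=O)c(SCc3ccccc3)cc2Cl)o1`: 120000 nM
- compound 2 `NS(=O)(=O)c1cc(-c2nnc(/C=C/c3ccccc3)o2)c(Cl)cc1SCc1ccccc1`: 18000 nM

Among the measured compounds shown here, compound 2 gives the lower of the two numbers in this assay; its only neighbour is compound 1, and the step of a 6.7-fold lower number from compound 1 to compound 2 (0.82 log units; beyond the scatter) separates them. Compound 3 `NS(=O)(=O)c1cc(-c2nnc(/C=C/c3cccc(Cl)c3)o2)c(Cl)cc1SCc1ccccc1` differs from compound 2 by chloro in place of hydrogen on an aromatic carbon. For the measured compounds named here, no measured step involves a change of this kind, so the one known step gives no direct guide. The number for compound 3 is therefore expected to stay close to that of compound 2, with a step of no change at the digits printed from compound 2 to compound 3 (within the scatter) not beyond the scatter. The estimate for compound 3 is 18000 nM, with a range from 6000 nM to 50000 nM.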

Compound 3, half-maximal inhibitory concentration: 12000 nM
The estimate for compound 3 lay 1.5-fold (0.18 log units) above the measured number, within the range that was stated.
By their numbers in this assay, from the lowest: compounds 3 and 2 (each within the scatter of the next); then compound 1.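

In this assay, turning phenyl into 3-chlorophenyl gives a 1.5-fold lower number from compound 2 to compound 3 (0.18 log units; within the scatter), so this one chlorine does not separate the two compounds. Replacing aminomethyl with 2-(3-chlorophenyl)ethenyl gives a 10-fold lower number from compound 1 to compound 3 (1.00 log units; beyond the scatter), which shows that the clear difference still lies with the swap of the whole group and not with the added chloro. No measurement at hand explains either step. The compounds shown leave open whether a methoxy group or a carboxylic acid at this place would move the number beyond the scatter. They also leave open whether chloro at another place on this ring would read the same.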